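Benzyl ring variation on the shared nucleoside core

This account rests on a few compounds, and the source may have more. Where it says the series, first, only, none or still open, it means among the compounds named here.

Measured compounds:
compound 1 `OC[C@H]1O[C@@H](n2cnc3c(NCc4ccc(F)cc4)ncnc32)[C@H](O)[C@@H]1O` — 1250 nM
compound 2 `OC[C@H]1O[C@@H](n2cnc3c(NCc4ccc(Br)cc4)ncnc32)[C@H](O)[C@@H]1O` — 20600 nM

In a functional assay on CCRF-CEM cells (Homo sapiens) for antiproliferative activity, with a stated time of 72 h (a lower number here means a stronger inhibitor, a higher number a weaker inhibitor), compound 2 gives 20600 nM, the highest of the two numbers; compound 1 gives 1250 nM. Going by the values given here, the only measured step is a 16-fold higher number from compound 1 to compound 2 (1.22 log units; beyond the scatter). Compound 3 `OC[C@H]1O[C@@H](n2cnc3c(NCc4c(F)ccc(F)c4F)ncnc32)[C@H](O)[C@@H]1O` differs from compound 2 by 2,3,6-trifluorophenyl in place of 4-bromophenyl on a saturated chain carbon bound to a nitrogen on an aromatic ring. That one step bears on the change only indirectly, since the 4-bromophenyl leaves and a fluorine-bearing ring enters again; a lower number than for compound 2 is expected in this assay, though not necessarily as low as for compound 1. Compound 3 is estimated at 3000 nM (range 600 nM to 15000 nM), an expected step of a 6.9-fold lower number from compound 2 to compound 3 (0.84 log units; beyond the scatter).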

Compound 3, half-maximal inhibitory concentration: 90300 nM
The estimate for compound 3 lay 30-fold (1.48 log units) below the measured number; the measured number lies above the stated range.
By their numbers in this assay, from the lowest: compound 1; then compound 2; then compound 3.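

Fluorine on the ring does not by itself keep the number low at this position: with 2,3,6-trifluorophenyl on the saturated chain carbon, this assay shows a 4.4-fold higher number from compound 2 to compound 3 (0.64 log units; beyond the scatter) and a 72-fold higher number from compound 1 to compound 3 (1.86 log units; beyond the scatter) in the same direction. Fluorine-bearing rings now stand at both ends of the order, with the 4-bromophenyl of compound 2 between them. No measurement at hand accounts for this order.

The compounds shown leave open whether the rise follows the number of fluorines or where they sit on the ring. Going by these compounds, how a ring carrying a methoxy group, an amine or a carboxylic acid would compare also remains open.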